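Thiophenylmethyl amide in place of 3-chlorophenyl amide

The source may report more compounds than this note shows. Statements on the series, on what has been measured and on what is new or still open speak of the compounds shown alone.

Measured compounds:
Compound 1, `COc1cc(-c2cc(C(=O)O)c3ccccc3n2)ccc1OCC(=O)Nc1ccccc1`, 0.7
Compound 2, `COc1cc(-c2cc(C(=O)O)c3ccccc3n2)ccc1OCC(=O)Nc1cccc(Cl)c1`, 2.3
Compound 3, `COc1cc(-c2cc(C(=O)O)c3ccccc3n2)ccc1OCC(=O)NCc1ccccc1`, 0.4

In a physicochemical assay for lipophilicity, using the shake flask method, in phosphate buffer, measured as octanol-water partition, at pH 7.4 (a higher number here means a more lipophilic compound, a lower number a more polar compound), compound 2 gives 2.3, the highest of the three numbers; the nearest is compound 1 with 0.7, and compound 3 with 0.4 lies furthest away. One step was a number 1.60 log units higher from compound 1 to compound 2 (beyond the scatter) and the other was a number 1.90 log units lower from compound 2 to compound 3 (beyond the scatter), both beyond the scatter.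

Compound 4, `COc1cc(-c2cc(C(=O)O)c3ccccc3n2)ccc1OCC(=O)NCc1cccs1`, is not yet measured. It differs from compound 2 in one place: (thiophen-2-yl)methyl in place of 3-chlorophenyl on an amide-type nitrogen.

For the measured compounds named here, two measured steps bear on this. Putting the chlorine in place of hydrogen alone gave a number 1.60 log units higher from compound 1 to compound 2 (beyond the scatter), and the move from 3-chlorophenyl to benzyl gave a number 1.90 log units lower from compound 2 to compound 3 (beyond the scatter). The change to compound 4 again removes the chlorine and again puts a methylene between the nitrogen and the aromatic ring, so a large downward step is expected. The expected step is a number 2.10 log units lower from compound 2 to compound 4 (beyond the scatter), and compound 4 is estimated at 0.2, within a range of -0.4 to 0.8.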

Compound 4, distribution coefficient: 0
The estimate for compound 4 lay 0.20 log units above the measured number, and the stated range covers the measured number.
By their numbers in this assay, from the lowest: compound 4; then compounds 3 and 1 (each within the scatter of the next); then compound 2.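

In this assay, the aromatic ring carried on the methylene at this amide nitrogen proves able to shift the number: thiophen-2-yl in place of phenyl gave a number 0.40 log units lower from compound 3 to compound 4 (beyond the scatter), whereas the earlier change from phenyl to benzyl stayed within the scatter. With (thiophen-2-yl)methyl in place of phenyl, the result is a number 0.70 log units lower from compound 1 to compound 4 (beyond the scatter), and replacing 3-chlorophenyl gives a number 2.30 log units lower from compound 2 to compound 4 (beyond the scatter), the largest step at this nitrogen among the compounds shown. No measurement here accounts for these steps.

The compounds shown leave open whether a chlorine on the benzyl ring of compound 3 or on the thiophene ring of compound 4 would raise the number as it did from compound 1 to compound 2. They also leave open how a pyridine ring or a longer chain would behave at this nitrogen.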